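The source may hold more compounds than are shown below. What is called first, only, known or untested is meant among the compounds shown, and "the series" means these compounds.

Compound 1 `Cc1ccc2[nH]c(C(=O)N[C@H]3CN(S(=O)(=O)c4ccccc4)C[C@@H]3C(=O)N[C@H]3CCCN(C)C3)cc2c1` and compound 2 `Cc1ccc2[nH]c(C(=O)N[C@H]3CN(S(=O)(=O)c4ccccc4)C[C@@H]3C(=O)N[C@H]3CCCNC3)cc2c1` share one core and differ only in hydrogen in place of methyl on an amine nitrogen in a ring. In a physicochemical assay for lipophilicity, measured as octanol-water partition, at pH 7.4 (on this read-out higher numbers stand for higher lipophilicity and lower numbers for lower lipophilicity), compound 1 gives 2.7, and in the same measurement compound 2 gives 1.3. That single change produced a number 1.40 log units lower from compound 1 to compound 2 (beyond the scatter).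

Compound 3 `Cc1ccc2[nH]c(C(=O)N[C@H]3CCN(S(=O)(=O)c4ccccc4Cl)C[C@@H]3C(=O)N[C@H]3CCCN(C)C3)cc2c1` is built on a different core; the difference between the two cores is not broken down here. In this assay compound 3 gives 3.1, the highest of the three numbers, standing beyond the scatter above both compound 1 and compound 2.

Compound 4 `Cc1ccc2[nH]c(C(=O)N[C@H]3CCN(S(=O)(=O)c4ccccc4Cl)C[C@@H]3C(=O)N[C@H]3CCCNC3)cc2c1` has not yet been measured. It differs from compound 3 by hydrogen in place of methyl on an amine nitrogen in a ring, the same change that separates compound 1 from compound 2, made at the same place on the ring. Because that change gave a number 1.40 log units lower from compound 1 to compound 2 (beyond the scatter), compound 4 is expected to show a step of about a number 1.40 log units lower from compound 3 to compound 4 (beyond the scatter). On this basis compound 4 is estimated to land near 1.7 in this assay, most likely between 1.3 and 2.1, to be checked once the measurement is in hand.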

Compound 4, distribution coefficient: 1.9
Estimate against measurement, compound 4: 0.20 log units below, within the range that was stated.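

In this assay, putting hydrogen in place of methyl on the amine nitrogen of the ring gave a number 1.20 log units lower from compound 3 to compound 4 (beyond the scatter) on the second core, and the same change on the first core gave a number 1.40 log units lower from compound 1 to compound 2 (beyond the scatter), so in both pairs the number fell by a large step, beyond the scatter. Going by these compounds alone, this shows that the change carried over in direction and broadly in size between these two cores, but with only two pairs it does not show that it would carry over to any other core. Nothing given here explains why the step took this size on either core.

The compounds shown leave open how the read-out would respond if that ring nitrogen carried something other than methyl or hydrogen, such as an ethyl group or an acetyl group. They also leave open how the step would read on a core that shares only part of the difference between these two cores.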